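A few compounds are considered here, and "the series" means these few. Any claim that something is new, unique, unknown or untested is made for them only; others in the source may bear on it.

Measured compounds:
compound 1 `COc1ccc(-c2cnc(NC(=O)c3ccc(Br)cc3)n2C)cc1` — > 100000 nM
compound 2 `Cc1ccc(-c2cnc(NC(=O)c3ccc(F)cc3)n2C)cc1` — 60000 nM

Both were tested in a toxicity assay on THP-1 cells (Homo sapiens) for inhibition; on this read-out lower numbers stand for higher toxicity in this test and higher numbers for lower toxicity in this test. For compound 1 the result is only a limit of the assay and not a number: > 100000 nM, which is the point described by the limit of > 100000 nM in this assay, at which 1 of the 2 values shown sits. Compound 2 gives 60000 nM in this assay, a measured number and not a limit. Compound 1 thus stands at the edge of what this assay reports, on the side of lowest toxicity. For the measured compounds named here, no step between two measured compounds that differ in one place is available, so nothing measured yet shows how a change on the carbonyl carbon moves the read-out.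

Compound 3 `COc1ccc(-c2cnc(NC(=O)c3cccc(OC)c3)n2C)cc1` has not yet been measured. It differs from compound 1 in this way: 3-methoxyphenyl in place of 4-bromophenyl on a carbonyl carbon. Since compound 1 sits at the limit (the limit of > 100000 nM in this assay, at which 1 of the 2 values shown sits), the step is expected to be small, none beyond the usual scatter: an at least 1.1-fold lower number from compound 1 to compound 3 (0.04 log units; that floor lies within the scatter). A limit is again likely. Compound 3 is expected to give 90000 nM in this assay, within 30000 nM to 300000 nM.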

Compound 3, half-maximal cytotoxic concentration: > 100000 nM
Compound 3 ended at the assay's limit; the forecaster's own chance of this, stated with the estimate: 55%; middle value at least 1.1-fold (0.04 log units) from the limit.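

Compound 1 and compound 3 both give only a limit and not a number in this assay, so no step between them can be read: the limit of > 100000 nM in this assay, at which 2 of the 3 values shown sit.

The compounds shown leave open how 3-methoxyphenyl in place of 4-bromophenyl on a carbonyl carbon moves this read-out.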